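The source may report more compounds than this note shows. Statements on the series, on what has been measured and on what is new or still open speak of the compounds shown alone.

Measured compounds in a functional assay on HEK293 cells for agonist activity at D(4) dopamine receptor (Homo sapiens), read by FLIPR; a higher number here means that more compound is needed for the effect, a lower number that less compound is needed:

compound 1, `Cc1cccc(NC(=O)CN2CCC(c3ccc(O)cc3)CC2)c1`: 70 nM
compound 2, `O=C(CN1CCC(c2cccc[n+]2[O-])CC1)Nc1cc(Cl)cc(Cl)c1`: 160 nM
compound 3, `N#Cc1cccc(C(=O)NCN2CCC(c3cccc[n+]3[O-])CC2)c1`: 840 nM

Compound 2 sits second highest of the three numbers in this assay; compound 1 gives the nearest number and compound 3 the furthest, both differences beyond the scatter. For the measured compounds named here, no single-point step between measured compounds is available.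

Compound 4, `CSc1cccc(NC(=O)CN2CCC(c3cccc[n+]3[O-])CC2)c1`, is not yet measured. It differs from compound 2 by 3-(methylsulfanyl)phenyl in place of 3,5-dichlorophenyl on an amide-type nitrogen; the rest of the structure is unchanged. With no measured step of this kind in the set, the expected step from compound 2 to compound 4 in this assay is a 1.1-fold lower number from compound 2 to compound 4 (0.03 log units; within the scatter), no clear direction, likely within the scatter. The estimate for compound 4 is 150 nM, with a range from 50 nM to 500 nM.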

Compound 4, half-maximal effective concentration: 100 nM
Estimate against measurement, compound 4: 1.5-fold (0.18 log units) above; measured number inside the range.
By their numbers in this assay, from the lowest: compounds 1, 4 and 2 (each within the scatter of the next, the first and the last beyond it); then compound 3.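

For the compounds shown here, on an amide-type nitrogen, 3-(methylsulfanyl)phenyl in place of 3,5-dichlorophenyl gives (a 1.6-fold lower number from compound 2 to compound 4 (0.20 log units; within the scatter)) in this assay, the first single-place step. At this position, then, the two groups cannot be told apart in this read-out, although the entering group carries sulfur and one hydrogen-bond acceptor where the leaving group carries two chlorines and none. No measured property bears on this step.

Going by these compounds, whether an unsubstituted phenyl or a 3-methoxyphenyl on the same nitrogen would also stay within the scatter of compound 2 remains open. Also open, on these data alone, is whether the same change would read alike on the core of compound 1.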